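The source may hold more compounds than are shown below. What is called first, only, known or untested is meant among the compounds shown, and "the series" means these compounds.

Going by the values given here, compound 1, whose structure is `C=CCOC(=O)C1=C2C(=NC1=O)c1cccc3cccc2c13`, is one of two compounds measured in a functional assay on BXPC-3 cells (Homo sapiens) for antiproliferative activity, read by sulforhodamine B assay, with a stated time of 72 h; a lower number here means a stronger inhibitor, a higher number a weaker inhibitor. In that test compound 1 gives 4800 nM, the lower of the two numbers. The other, compound 2 with structure `CCCSc1ccc2c3c(cccc13)C1=NC(=O)C(C(=O)OCC(=O)OCC(F)(F)C(F)(F)F)=C12`, gives 54100 nM in this assay. Compound 2 carries a propylsulfanyl group and a different ester, so it differs from compound 1 in more than one place, and its higher number cannot be tied to a single change.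

Compound 3, with structure `C=CCOC(=O)C1=C2C(=NC1=O)c1cccc3c(SCC=C)ccc2c13`, keeps the core and ester of compound 1 and adds one group: allylsulfanyl in place of hydrogen on an aromatic carbon. Among the compounds with values here, no measured pair isolates such a change. Within the data shown here, the only hint is compound 2, whose value of 54100 nM comes with a sulfur-linked chain, but also with another ester. The step of a 1.9-fold higher number from compound 1 to compound 3 (0.27 log units; within the scatter) is therefore expected to be a modest weakening, with wide uncertainty. Compound 3 is estimated at 9000 nM, likely between 3000 nM and 30000 nM.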

Compound 3, half-maximal inhibitory concentration: 2500 nM
Estimate against measurement, compound 3: 3.6-fold (0.56 log units) above, and the stated range ends above it.
By their numbers in this assay, from the lowest: compounds 3 and 1 (each within the scatter of the next); then compound 2.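

In this assay the allylsulfanyl group in place of hydrogen on an aromatic carbon gives a 1.9-fold lower number from compound 1 to compound 3 (0.28 log units; within the scatter) and so leaves compound 1 and compound 3 indistinguishable in this test. This is the only pair shown that isolates a sulfur-linked chain on the shared core, and it shows that this aromatic carbon can carry such a chain without a loss of activity that the assay can detect. No measurement is available to explain this result.

Still open, as far as these compounds go, is whether other groups on this same carbon, such as an amine, a carboxylic acid or a longer chain, would also stay within the scatter of compound 1. Also open, from the compounds shown here alone, is whether allylsulfanyl would give the same result alongside a different ester.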